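The source may report more compounds than this note shows. Statements on the series, on what has been measured and on what is new or still open speak of the compounds shown alone.

Measured compounds in an assay on microsomes from intestine for inhibition of acyl-CoA:cholesterol acyltransferase (Oryctolagus cuniculus); a lower number here means a stronger inhibitor, a higher number a weaker inhibitor:
compound 1 `CCCCCCCC/C=C/CCCCCCCC(=O)Nc1ccccc1OC`, 8000 nM
compound 2 `CCCCCCCC/C=C/CCCCCCCC(=O)Nc1ccccc1C(C)C`, 600 nM
compound 3 `CCCCCCCC/C=C/CCCCCCCC(=O)Nc1cccc(C)c1[N+](=O)[O-]`, 12000 nM

Compound 1 holds the second highest number of the three in this assay. Within the data shown here, the step of a 1.5-fold higher number from compound 1 to compound 3 (0.18 log units; within the scatter) is within the scatter, whereas the step of a 13-fold lower number from compound 1 to compound 2 (1.12 log units; beyond the scatter) is large and is the only change in this set that lowers the number beyond the scatter.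

Compound 4 `CCCCCCCC/C=C/CCCCCCCC(=O)Nc1c(C)cccc1C(C)C` differs from compound 1 by a group of 10 heavy atoms (10 carbon; one six-membered aromatic ring of carbon only) in place of a group of 8 heavy atoms (7 carbon, 1 oxygen; one six-membered aromatic ring of carbon only), on an amide-type nitrogen. The entering group carries the isopropyl whose introduction gave a 13-fold lower number from compound 1 to compound 2 (1.12 log units; beyond the scatter), so that step bears directly on the change; the step of a 20-fold higher number from compound 2 to compound 3 (1.30 log units; beyond the scatter) points the same way. Among the measured compounds shown here, the methyl that also enters has no measured counterpart here, and its contribution is unknown. A large step down in this assay is expected, at least of the size of the isopropyl step. Compound 4 is therefore estimated at 300 nM (range 80 nM to 1500 nM), an expected step of a 27-fold lower number from compound 1 to compound 4 (1.43 log units; beyond the scatter).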

Compound 4, half-maximal inhibitory concentration: 23 nM
Estimate against measurement, compound 4: 13-fold (1.12 log units) above; measured number outside the range, below it.
By their numbers in this assay, from the lowest: compound 4; then compound 2; then compounds 1 and 3 (each within the scatter of the next).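

In this assay, methyl in place of hydrogen on an aromatic carbon gives a 26-fold lower number from compound 2 to compound 4 (1.42 log units; beyond the scatter) and is thus a large step in its own right, not a minor addition to the isopropyl change. With both groups present, the change on the amide-type nitrogen reaches a 350-fold lower number from compound 1 to compound 4 (2.54 log units; beyond the scatter) and, against the 3-methyl-2-nitrophenyl group, a 520-fold lower number from compound 3 to compound 4 (2.72 log units; beyond the scatter) in the same assay. The series therefore gains most where isopropyl and methyl occur together.

As far as these compounds go, whether ethyl or chlorine in place of that methyl would keep the number this low remains open. No evidence is available on what lies behind the methyl step.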